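The compounds below may be only part of what the source reports. "The series", "measured", "known", "first", "only" and "open" are said of these compounds alone.

Measured compounds:
compound 1 `Cc1ccc(S(=O)(=O)n2c(-c3ccccc3)c(C#CCO[C@H]3CC[C@H](N)[C@H](C)O3)c3ccccc32)cc1` — 43.2%
compound 2 `C[C@@H]1O[C@@H](OCC#Cc2c(-c3ccccc3)sc3ccccc23)C[C@H](N)[C@H]1O` — 32.2%
compound 3 `C[C@@H]1O[C@@H](OCC#Cc2c(-c3ccccc3)oc3ccccc23)C[C@H](N)[C@@H]1O` — 77.8%

All three were tested in an assay on isolated protein for inhibition of DNA topoisomerase 1 (Homo sapiens), with a stated time of 30 min, tested at 100 uM; a lower number here means less inhibition, a higher number more inhibition at the concentration tested (going by the name of the read-out). Among them, compound 1 stands second highest of the three numbers: its nearest neighbour is compound 2, whose number is lower by a margin beyond the scatter, and the furthest is compound 3, whose number is higher by a margin well beyond the scatter. For the measured compounds named here, no pair of measured compounds differs in only one place, so no single step within the measured set can be read directly.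

The unmeasured compound 4 `Cc1ccc(S(=O)(=O)n2c(-c3ccccc3)c(C#CCO[C@H]3C[C@H](N)[C@@H](O)[C@H](C)O3)c3ccccc32)cc1` is reached from compound 1 by one change: a group of 9 heavy atoms (6 carbon, 1 nitrogen, 2 oxygen; one six-membered non-aromatic ring with 1 hetero atom) in place of a group of 8 heavy atoms (6 carbon, 1 nitrogen, 1 oxygen; one six-membered non-aromatic ring with 1 hetero atom), on an oxygen on a saturated carbon The core of compound 1 is kept, and the change touches only the ring carried on the propargylic oxygen. Compounds 2 and 3 both carry the entering ring, yet they sit far apart from each other, so they do not fix the direction for compound 4.

The writer expects a step from compound 1 to compound 4 in this assay of modest size, most likely upward, estimated as a number 8.8 percentage points higher from compound 1 to compound 4 (within the scatter). Compound 4 is therefore expected to give about 52%, with a likely range from 28% to 76%.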

Compound 4, a percentage reported as inhibition, at one concentration (the size of the read-out at that concentration, not a potency): 92.8%
The estimate for compound 4 lay 40.8 percentage points below the measured number, and the stated range ends below it.
By their numbers in this assay, from the lowest: compound 2; then compound 1; then compound 3; then compound 4.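

In this assay, the ring carried on the propargylic oxygen proves to be a sensitive position: with the core of compound 1 kept, one change at this place gives a large step, a number 49.6 percentage points higher from compound 1 to compound 4 (beyond the scatter), beyond the scatter. The earlier compounds shown here could not show this, since no two of them differed in only one place, so the weight of this ring alone could not be read from them. The ring that enters keeps the six-membered non-aromatic form of the ring that leaves the 5-amino-6-methyloxan-2-yl position, but it has 9 heavy atoms instead of 8, 2 hydrogen-bond donors instead of 1 and 4 defined stereocentres instead of 3, and nothing given here accounts for the step.

The compounds shown leave open whether the step depends on the added oxygen itself, for example whether a methoxy group or a second amine at that ring position would give a similar number. They also leave open whether the same ring change would give a step of this size on a core other than that of compound 1, and how the arrangement of the stereocentres in the ring contributes.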